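The source may report more compounds than this note shows. Statements on the series, on what has been measured and on what is new or still open speak of the compounds shown alone.

Compound 2 `COc1c(C)cnc(CN2CC(=O)N(CC(C)C)c3c(Cl)nc(N)nc32)c1C` gives the lowest number of the three measured compounds in a functional assay on MCF7 cells (Homo sapiens) for inhibition (on this read-out lower numbers stand for stronger inhibition and higher numbers for weaker inhibition), at 70 nM. Compound 1 `Cc1cnc(CN2CC(=O)N(CC(C)C)c3c(Cl)nc(N)nc32)c(C)c1Br` carries a bromo where compound 2 carries a methoxy; in this assay compound 1 gives 280 nM, and the step of a 4.0-fold lower number from compound 1 to compound 2 (0.60 log units; beyond the scatter). Compound 3 `COc1c(C)cnc(CN2c3nc(N)nc(Cl)c3NC(=O)[C@H]2C)c1C` differs from compound 2 in more than one place; in this assay compound 3 gives 790 nM, a higher number than either of the other two. Compound 4 `COc1c(C)cnc(CN2CC(=O)N(C(C)C)c3c(Cl)nc(N)nc32)c1C` has not yet been measured. It differs from compound 2 by isopropyl in place of isobutyl on an amide-type nitrogen in a ring. Among the measured compounds shown here, the only measured step, from compound 1 to compound 2, concerns a group on an aromatic carbon and says nothing about the group on the amide-type nitrogen in a ring, and compound 3 changes several places at once, so it offers no separate reading on this nitrogen either. With nothing measured bearing on the change, the step is expected to stay within the scatter, and the expected step is a 1.6-fold higher number from compound 2 to compound 4 (0.20 log units; within the scatter). Compound 4 is therefore estimated at 110 nM, with a range from 40 nM to 350 nM.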

Compound 4, half-maximal inhibitory concentration: 50 nM
For compound 4 the middle estimate is 2.2-fold (0.34 log units) above the measured one, within the range that was stated.
By their numbers in this assay, from the lowest: compounds 4 and 2 (each within the scatter of the next); then compound 1; then compound 3.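

In this assay, replacing isobutyl with isopropyl on the amide-type nitrogen in a ring gives a 1.4-fold lower number from compound 2 to compound 4 (0.15 log units; within the scatter), so the two groups cannot be told apart at this position. This is the first reading on that nitrogen among the compounds shown, and it indicates that, with the rest of compound 2 unchanged, the 3-carbon isopropyl serves as well as the 4-carbon isobutyl in this assay. The data shown offer no measured explanation for this result.

What the compounds shown leave open is whether this tolerance extends to a methyl group, a longer chain, a cyclohexyl ring or a chain ending in an amine or a carboxylic acid on this nitrogen. They also leave open whether isopropyl and isobutyl would remain indistinguishable with bromo in place of the methoxy.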